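Dropping the Chloro Group: From Compound 2 to Compound 3

A few compounds are considered here, and "the series" means these few. Any claim that something is new, unique, unknown or untested is made for them only; others in the source may bear on it.

Of the compounds shown here, two have been measured so far. Compound 2 `NC1=N[C@@H](c2ccccc2Cl)CO1` and compound 1 `CCN(C[C@@H]1COC(N)=N1)c1ccccc1` were both tested in a functional assay on HEK293 cells for agonist activity at trace amine-associated receptor 1 (Homo sapiens), read by cAMP accumulation, with a stated time of 30 min; a lower number here means a smaller maximal response, a higher number a larger maximal response. Compound 2 gives 100% and stands at the top of the two numbers seen, while compound 1 gives 94%, a number that lies within the scatter of compound 2, so the two cannot be told apart. Compound 3 `NC1=N[C@@H](c2ccccc2)CO1` has not yet been tested. It differs from compound 2 in a single place: hydrogen in place of chloro on an aromatic carbon. No step between measured compounds has been shown, so the expected size of the step rests only on the structural change and on the two numbers at hand. Because compound 2 gives 100%, a full response, a step of a number 5 percentage points lower from compound 2 to compound 3 (within the scatter) is expected, none beyond the scatter. For compound 3 a value of 95% is estimated, between 80% and 105%.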

Compound 3, largest response reached (Emax), in percent of the reference or control that the assay uses: 104%
Compound 3: middle estimate off by 9 percentage points, on the low side, within the range that was stated.
By their numbers in this assay, from the lowest: compounds 1, 2 and 3 (each within the scatter of the next).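

In this assay, among the compounds shown here, the exchange of chloro for hydrogen gives a number 4 percentage points higher from compound 2 to compound 3 (within the scatter), so this is the first step seen at this position, and it cannot be told apart from no step at all. The chloro group on this aromatic carbon is therefore not required for a full response: compound 3, which carries only hydrogen there, reaches 104%. No measurement at hand offers any explanation for this result.

Going by these compounds, whether a methyl group, a methoxy group or an amine on the same aromatic carbon would also leave the response within the scatter remains open. The largest response also says nothing about the concentration needed to reach it, so compound 2 and compound 3 could still differ in that respect.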